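Swapping Methoxy for Chloro on the Phenyl Ring

The compounds below may be only part of what the source reports. "The series", "measured", "known", "first", "only" and "open" are said of these compounds alone.

Among the compounds with values here, compound 3 `COc1ccc(-c2cc(/N=C3\SCC(=O)N3c3cccc(OC)c3)cs2)cc1` is the only compound here with a single number: in a functional assay on SW-620 cells (Homo sapiens) for cytotoxicity, read by MTT assay, with a stated time of 72 h (on this read-out lower numbers stand for stronger inhibition and higher numbers for weaker inhibition), compound 3 gives 3500 nM. Compound 2 `COc1cccc(N2C(=O)CS/C2=N\c2csc(-c3ccc(C)cc3)c2)c1` reaches only a limit of this assay, > 50000 nM. For compound 1 `COc1cccc(N2C(=O)CS/C2=N\c2csc(-c3ccccc3)c2)c1` this assay reports "not determined" (no result reported). Within the data shown here, the one measured step, an at least 14-fold lower number from compound 2 to compound 3 (1.15 log units; beyond the scatter), shows that methoxy in place of methyl made the inhibition much stronger. Compound 4 `COc1cccc(N2C(=O)CS/C2=N\c2csc(-c3ccc(Cl)cc3)c2)c1` moves the other way: chloro in place of methoxy on an aromatic carbon. Compound 2 also carries no methoxy and stands at the limit (the limit of > 50000 nM in this assay, at which 1 of the 3 values shown sits), so removing the methoxy is expected to raise the number. Compound 4 is therefore estimated at 15000 nM, within a range from 4000 nM to 60000 nM. That expected step is a 4.3-fold higher number from compound 3 to compound 4 (0.63 log units; beyond the scatter).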

Compound 4, half-maximal inhibitory concentration: 33000 nM
The estimate for compound 4 lay 2.2-fold (0.34 log units) below the measured number; the measured number falls inside the stated range.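

At this aromatic carbon, chloro does not keep what methoxy gave: the swap brings a 9.4-fold higher number from compound 3 to compound 4 (0.97 log units; beyond the scatter). Among the groups compared here, the lower number therefore goes with methoxy, not with just any group at this place. Chloro in place of methyl gives an at least 1.5-fold lower number from compound 2 to compound 4 (0.18 log units; that floor lies within the scatter), so these two groups cannot be ranked, because compound 2 sits at a limit: the limit of > 50000 nM in this assay, at which 1 of the 4 values shown sits.

As far as these compounds go, whether a hydroxy group, an amine or the longer ethoxy group at this place would match methoxy stays open.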